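The compounds below may be only part of what the source reports. "The series", "measured", "known", "first", "only" and "open" are said of these compounds alone.

Compound 1 `Cc1ccc(S(=O)(=O)N2CC=C(Br)CC2)cc1` gives > 100000 nM in a functional assay on A2780 cells (Homo sapiens) for antiproliferative activity, read by sulforhodamine B assay, with a stated time of 48 h (on this read-out higher numbers stand for weaker inhibition of growth and lower numbers for stronger inhibition of growth), a limit of the assay. Compound 2 `CCCCCCCC1C=C(Br)CCN1S(=O)(=O)c1ccc(C)cc1` gives > 100000 nM, likewise a limit. Compound 2 therefore stands at the limit of > 100000 nM in this assay, at which 2 of the 2 values shown sit, with no number read. The step that the two limits leave unreadable from compound 1 to compound 2 cannot be sized from two limits. Compound 3 `Cc1ccc(S(=O)(=O)N2CCC(Br)=CC2C2CCCCC2)cc1` differs from compound 2 by cyclohexyl in place of heptyl on a saturated ring carbon. No readable measured step bears on this change, so no shift beyond the limit can be foreseen. The step from compound 2 to compound 3 is expected to be a number no higher from compound 2 to compound 3 (the limit leaves the size open). Compound 3 is estimated at 100000 nM, ranging from 30000 nM to 300000 nM, most likely again a limit.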

Compound 3, concentration for 50% growth inhibition: 44000 nM
Compound 3: the middle estimate sits 2.3-fold (0.36 log units) above what was measured; the range from low to high includes it.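

In this assay, among the compounds shown here, cyclohexyl is the first group at this saturated ring carbon to bring growth inhibition within measurable range: in place of heptyl it gives an at least 2.2-fold lower number from compound 2 to compound 3 (0.35 log units; beyond the scatter), and in place of hydrogen it gives an at least 2.2-fold lower number from compound 1 to compound 3 (0.35 log units; beyond the scatter). Thus, a group with a ring gave a reading here, whereas heptyl, with no ring, did not. Both steps are only minimum sizes, since compound 1 and compound 2 each stand at a limit: the limit of > 100000 nM in this assay, at which 2 of the 3 values shown sit.

Going by these compounds, whether a phenyl ring or a cyclopentyl ring would serve here as cyclohexyl does remains open. So does whether an amine or a carboxylic acid on the cyclohexyl would shift the value.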